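The source may report more compounds than this note shows. Statements on the series, on what has been measured and on what is new or still open speak of the compounds shown alone.

Measured compounds in this study:

- compound 1 `CN(C)CCCNc1nc(-c2ccc(NC(=O)Nc3ccccc3Cl)cc2)nc2c(Cl)c(Cl)sc12`: 1560 nM
- compound 2 `CN(C)CCCNc1nc(-c2ccc(NC(=O)Nc3ccc(Cl)cc3Cl)cc2)nc2c(Cl)c(Cl)sc12`: 3490 nM
- compound 3 `Cc1ccc(NC(=O)Nc2ccc(-c3nc(NCCCN(C)C)c4sc(Cl)c(Cl)c4n3)cc2)cc1`: 4980 nM

All three share one core and were tested in a functional assay on MDA-MB-231 cells (Homo sapiens) for cytotoxicity, read by MTT assay, with a stated time of 72 h; on this read-out lower numbers stand for stronger inhibition and higher numbers for weaker inhibition. Compound 1 gives the lowest number of the three. Its nearest neighbour is compound 2, with a 2.2-fold higher number from compound 1 to compound 2 (0.35 log units; beyond the scatter); the furthest is compound 3, with a 3.2-fold higher number from compound 1 to compound 3 (0.50 log units; beyond the scatter). Between the other two there is a 1.4-fold higher number from compound 2 to compound 3 (0.15 log units; within the scatter), so these two are not separated from each other.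

Compound 4 `CCN(CC)CCNc1nc(-c2ccc(NC(=O)Nc3ccccc3Cl)cc2)nc2c(Cl)c(Cl)sc12` has not yet been measured in this assay. It differs from compound 1 by diethylamino in place of (dimethylamino)methyl on a saturated chain carbon, two bonds along the chain from a nitrogen on an aromatic ring. Going by the values given here, none of the measured steps bears on this change: all three of them alter the aryl group on the urea, while the amine-bearing chain is the same in compounds 1, 2 and 3. The measured steps that exist are of modest size, and the change in compound 4 leaves the urea side untouched, so no step beyond the scatter is expected in this assay. On that basis compound 4 is estimated to give 1800 nM, with a range from 700 nM to 4500 nM. The expected step is therefore a 1.2-fold higher number from compound 1 to compound 4 (0.06 log units; within the scatter).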

Compound 4, half-maximal inhibitory concentration: 1410 nM
Estimate against measurement, compound 4: 1.3-fold (0.11 log units) above; measured number inside the range.
By their numbers in this assay, from the lowest: compounds 4 and 1 (each within the scatter of the next); then compounds 2 and 3 (each within the scatter of the next).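

Going by these compounds alone, compound 4 is the first compound here in which the amine-bearing chain changes rather than the aryl group on the urea, and in this assay the exchange of (3-(dimethylamino)propyl)amino for (2-(diethylamino)ethyl)amino gives a 1.1-fold lower number from compound 1 to compound 4 (0.04 log units; within the scatter) and so does not separate the two compounds. At this place, then, a chain with a diethylamino end can stand in for the 3-(dimethylamino)propyl chain of compound 1 with no step beyond the scatter, whereas the changes to the aryl group on the urea that lead from compound 1 to compounds 2 and 3 do give such steps. No measurement on these groups is available that would account for this result.

The exchange alters the chain and the groups on its nitrogen together, so the compounds shown do not tell the two apart, which a diethylamino group on the longer chain or a dimethylamino group on the shorter one would do. Also open, going by these compounds, are a ring amine such as morpholine or piperidine at the chain end, and whether the result holds with the 2,4-dichlorophenyl or 4-methylphenyl group on the urea.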